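Phenoxy group exchange on the shared core: working notes

The source may hold more compounds than are shown below. What is called first, only, known or untested is meant among the compounds shown, and "the series" means these compounds.

Measured so far in a functional assay with Homo sapiens as the target; on this read-out lower numbers stand for stronger inhibition and higher numbers for weaker inhibition:
- compound 1 `CC(C)[C@H](NC(=O)COc1cccc2ccccc12)C(=O)N[C@@H](CC(=O)O)C(=O)COc1ccc(F)cc1F` gives 17600 nM in this read-out
- compound 2 `CC(C)[C@H](NC(=O)COc1cccc2ccccc12)C(=O)N[C@@H](CC(=O)O)C(=O)COc1cc(F)cc(F)c1F` gives 11200 nM in this read-out

Compound 2 stands within the scatter of compound 1, so neither ranks ahead of the other. The next change leads to compound 3 `CC(C)[C@H](NC(=O)COc1cccc2ccccc12)C(=O)N[C@@H](CC(=O)O)C(=O)COc1c(Cl)cccc1Cl`, not yet measured (2,6-dichlorophenyl in place of 2,3,5-trifluorophenyl on an oxygen on a saturated carbon), with 2,6-dichlorophenyl in place of 2,3,5-trifluorophenyl on an oxygen on a saturated carbon. For the measured compounds named here, one measured step bears on this place: a 1.6-fold lower number from compound 1 to compound 2 (0.20 log units; within the scatter), which lies within the scatter. Going by the values given here, that step involves only fluorine-bearing groups, and no measured compound carries chlorine here, so the guidance is thin. No step beyond the scatter is therefore expected in this assay, only a wide margin on either side. The estimated step is a 1.0-fold lower number from compound 2 to compound 3 (0.01 log units; within the scatter) in size. For compound 3 the estimated value is 11000 nM, with an expected range of 3500 nM to 35000 nM in this read-out.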

Compound 3, half-maximal inhibitory concentration: 15300 nM
For compound 3 the middle estimate is 1.4-fold (0.14 log units) below the measured one; the measured number falls inside the stated range.
By their numbers in this assay, from the lowest: compounds 2, 3 and 1 (each within the scatter of the next).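

Compound 3 carries chlorine on the phenyl group where compound 1 and compound 2 carry fluorine, and in this assay this exchange still gives no step beyond the scatter: the change reads a 1.4-fold higher number from compound 2 to compound 3 (0.14 log units; within the scatter) and, against the 2,4-difluorophenyl group, a 1.2-fold lower number from compound 1 to compound 3 (0.06 log units; within the scatter) in size. All three phenyl groups on this oxygen on a saturated carbon therefore stand within the scatter of one another, so this set gives no ranking among the fluorine-bearing and chlorine-bearing groups. No supporting evidence bears on this result.

As far as these compounds go, it remains open whether any group at this position can move the number in this assay beyond the scatter, since all three groups here are halogen-bearing phenyl rings. A phenyl group bearing an amine or a methoxy group, or a saturated alkyl chain in place of the phenyl group, would test this.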